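Chlorophenyl to bromohydroxyphenyl on the same chain

A few compounds are considered here, and "the series" means these few. Any claim that something is new, unique, unknown or untested is made for them only; others in the source may bear on it.

Compound 1 `COc1ccc(C(=O)/C=C/c2ccccn2)c2c1C=CC(C)(C)O2` and compound 2 `COc1ccc(C(=O)/C=C/c2cccc(Cl)c2)c2c1C=CC(C)(C)O2` share one core and differ only in the aromatic ring that sits on the double-bonded chain. In a functional assay on K562 cells (Homo sapiens) for antiproliferative activity, read by MTT assay, with a stated time of 24 h (a higher number here means a weaker inhibitor, a lower number a stronger inhibitor), compound 1 gives 5400 nM. In this assay compound 2 reaches only the limit of the assay, reported as > 10000 nM, so where compound 2 truly stands is known as a floor and not as a number. The step of an at least 1.8-fold higher number from compound 1 to compound 2 (0.26 log units; that floor lies within the scatter) is thus itself only a floor, and the limit of > 10000 nM in this assay, at which 1 of the 2 values shown sits, is the reason a plain size cannot be given for it.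

Compound 3 `COc1ccc(C(=O)/C=C/c2ccc(O)c(Br)c2)c2c1C=CC(C)(C)O2` carries the change (3-bromo-4-hydroxyphenyl in place of 3-chlorophenyl on a double-bonded chain carbon bound to a double-bonded chain carbon). Among the measured compounds shown here, no measured pair involves the entering 3-bromo-4-hydroxyphenyl group, so the single step from compound 1 to compound 2 gives no guide to the direction or size of this move. The expected step is therefore a number no higher from compound 2 to compound 3 (the limit leaves the size open), taken as no change beyond the scatter from a floor. For compound 3 in this assay the estimate is 10000 nM, with a range from 3000 nM to 30000 nM, and a second reading at the limit is judged about as likely as a number.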

Compound 3, half-maximal inhibitory concentration: > 10000 nM
Compound 3 was reported as a limit; the forecaster's own chance of this, stated with the estimate: 55%; the middle value lies on the limit itself.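

Compound 3 joins compound 2 as a limit in this assay, so the change from 3-chlorophenyl to 3-bromo-4-hydroxyphenyl at this place has no readable size, and the direction of the step between the two cannot be told either, because both are reported only as limits: the limit of > 10000 nM in this assay, at which 2 of the 3 values shown sit.

Among the compounds shown here, the one step that can be read is an at least 1.8-fold higher number from compound 1 to compound 3 (0.26 log units; that floor lies within the scatter), and it is only a floor. What this adds is that a second kind of substituted phenyl ring on the chain, one with a bromine and a hydroxy group, also gives no number in this assay, which leaves the pyridin-2-yl of compound 1 as the only ring here with a measured number.

On these data alone, how far compound 2 and compound 3 truly lie from compound 1 stays open, as does what the hydroxy group and the bromine each contribute on their own. Also open, as far as these compounds go, is whether a phenyl ring carrying an amine or a carboxylic acid, or a pyridin-3-yl in place of the pyridin-2-yl, would give a number in this assay.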